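Tert-Butylphenyl Replaces Dimethylphenyl on the Sulfonamide Nitrogen

The compounds below may be only part of what the source reports. "The series", "measured", "known", "first", "only" and "open" are said of these compounds alone.

Compound 2 `Cc1ccc(C)c(NS(=O)(=O)c2cccc(CCCCCCNC(=O)/C=C/c3cccnc3)c2)c1` stands at the higher end of the two values shown: in an assay on isolated protein for inhibition of Nicotinamide phosphoribosyltransferase (Homo sapiens), read by WST assay, with stated times of 60 min, 5 min and 30 min, in the presence of a further agent that is not named here (on this read-out higher numbers stand for weaker inhibition and lower numbers for stronger inhibition), compound 2 gives 11.6 nM, whereas compound 1 `Cc1ccccc1NS(=O)(=O)c1cccc(CCCCCCNC(=O)/C=C/c2cccnc2)c1` gives 5.08 nM. Among the measured compounds shown here, the only step so far, a 2.3-fold higher number from compound 1 to compound 2 (0.36 log units; beyond the scatter), reached beyond the scatter but stayed modest. Compound 3 `CC(C)(C)c1ccc(NS(=O)(=O)c2cccc(CCCCCCNC(=O)/C=C/c3cccnc3)c2)cc1` differs from compound 2 by 4-(tert-butyl)phenyl in place of 2,5-dimethylphenyl on a sulfonamide nitrogen. For the measured compounds named here, no measured step covers an exchange of one aryl group for another; the sole step available, a 2.3-fold higher number from compound 1 to compound 2 (0.36 log units; beyond the scatter), accompanied a methyl entering on an aromatic carbon and moved the number upward by a modest amount. Replacing the whole aromatic group is therefore expected to shift this assay by a modest amount as well, most likely upward or within the scatter, with wide uncertainty. Compound 3 is accordingly estimated at 15 nM, within a range of 5 nM to 45 nM. That estimate would mean a step of a 1.3-fold higher number from compound 2 to compound 3 (0.11 log units; within the scatter).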

Compound 3, half-maximal inhibitory concentration: 9.47 nM
Estimate against measurement, compound 3: 1.6-fold (0.20 log units) above; the measured number falls inside the stated range.
By their numbers in this assay, from the lowest: compounds 1, 3 and 2 (each within the scatter of the next, the first and the last beyond it).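

In this assay the sulfonamide nitrogen tolerates the exchange of one whole aryl group for another: the step to 4-(tert-butyl)phenyl from 2,5-dimethylphenyl is a 1.2-fold lower number from compound 2 to compound 3 (0.09 log units; within the scatter) and the step from 2-methylphenyl is a 1.9-fold higher number from compound 1 to compound 3 (0.27 log units; within the scatter). Compound 3 thus cannot be told apart from either earlier compound, even though it carries the group with more heavy atoms and compound 1 and compound 2 themselves stand apart beyond the scatter. Nothing available accounts for this result.

On these data alone, whether an aryl group bearing a carboxylic acid or an amine would hold the number at this level remains open. So does whether a cyclohexyl group, with no aromatic ring on the sulfonamide nitrogen, would be tolerated in the same way.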